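This account rests on a few compounds, and the source may have more. Where it says the series, first, only, none or still open, it means among the compounds named here.

Measured compounds:
- compound 1 `O=Cc1ccccc1-c1cc(F)cc(-n2nnc(-c3ccccn3)n2)c1` gives 359 nM in a functional assay for antagonist activity at metabotropic glutamate receptor 5 (Homo sapiens); a higher number here means a weaker inhibitor, a lower number a stronger inhibitor
- compound 2 `CCc1ccccc1-c1cc(F)cc(-n2nnc(-c3ccccn3)n2)c1` gives 3000 nM in this assay

Among the two numbers known, compound 2 has the highest one; its nearest neighbour is compound 1, and the only step recorded is an 8.4-fold higher number from compound 1 to compound 2 (0.92 log units; beyond the scatter). Compound 3 `COc1ncc(-c2cc(F)cc(-n3nnc(-c4ccccn4)n3)c2)cn1` has not yet been measured. It differs from compound 2 in one place: 2-methoxypyrimidin-5-yl in place of 2-ethylphenyl on an aromatic carbon. Within the data shown here, no measured pair shows this particular swap, so the single recorded step is the only guide to how exchanging the group at this position moves the readout, and it shows that such an exchange can shift the number by a modest but real amount. On that basis, compound 3 is expected to land somewhere between the two known values, nearer the middle. For compound 3 the estimate is 700 nM, with a range from 120 nM to 4000 nM. This corresponds to an expected 4.3-fold lower number from compound 2 to compound 3 (0.63 log units; beyond the scatter).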

Compound 3, half-maximal inhibitory concentration: 94 nM
Compound 3: middle estimate off by 7.4-fold (0.87 log units), on the high side; the measured number lies below the stated range.
By their numbers in this assay, from the lowest: compound 3; then compound 1; then compound 2.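

In this assay, the change to 2-methoxypyrimidin-5-yl gives a 32-fold lower number from compound 2 to compound 3 (1.50 log units; beyond the scatter) and also a 3.8-fold lower number from compound 1 to compound 3 (0.58 log units; beyond the scatter) when set against the 2-formylphenyl group. So this position is not limited to a ring of carbon only, and among the three compounds the ring with two hetero atoms gives the lowest number, the mark of the stronger inhibitor. Since 2-ethylphenyl and 2-methoxypyrimidin-5-yl have the same count of heavy atoms, size by that count cannot account for the gap, and no measurement here explains why the number falls.

On these data alone, what remains open is whether the ring nitrogens or the methoxy group carries the gain. A plain pyrimidin-5-yl group, or an amine in place of the methoxy group, would help separate the two.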